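A Trifluoromethyl Added to the Piperidine Ring

This account rests on a few compounds, and the source may have more. Where it says the series, first, only, none or still open, it means among the compounds named here.

Four compounds share one core and differ mainly in the ring carried by the sulfonyl group. Compound 1 `CCn1nc(C(F)(F)F)cc1C(=O)Nc1ccc(S(=O)(=O)N2CCCCC2C)cc1` was tested in an ADME assay on Vero cells (Chlorocebus sabaeus) for cytotoxicity, read by MTT assay (a higher number here means that more compound is tolerated, a lower number that less compound is tolerated), where compound 1 gives 30000 nM. Compound 2 `O=C(O)c1ccccc1-n1nc(C(F)(F)F)cc1C(=O)Nc1ccc(S(=O)(=O)N2CCCC2)cc1` has in this assay only the entry "not determined" (no result reported). For compound 3 `Cn1nc(C(F)(F)F)cc1C(=O)Nc1ccc(S(=O)(=O)N2CCCCC2)cc1` this assay reports a limit rather than a number, > 300000 nM. Compound 3 thus stands at the limit of > 300000 nM in this assay, at which 1 of the 3 values shown sits. Compound 1 and compound 3 cannot be compared as a step here, and compound 2 offers no number at all, so compound 3 stands as the best-tolerated point on the numbers shown, though only as a limit.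

Compound 4 `Cn1nc(C(F)(F)F)cc1C(=O)Nc1ccc(S(=O)(=O)N2CCC(C(F)(F)F)CC2)cc1` differs from compound 3 by trifluoromethyl in place of hydrogen on a saturated ring carbon. For the measured compounds named here, no measured pair shows what this change does in this assay. The expectation is that the step from compound 3 to compound 4 in this assay, an at least 1.5-fold lower number from compound 3 to compound 4 (0.17 log units; that floor lies within the scatter), stays within the scatter or is a modest fall in tolerance. Compound 4 is therefore expected to give about 200000 nM, in a range from 60000 nM to 400000 nM.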

Compound 4, half-maximal cytotoxic concentration: 159000 nM
Beside the measured number, compound 4's estimate is 1.3-fold (0.10 log units) above it, within the range that was stated.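

In this assay, for the compounds shown here, the first measured step at this ring carbon, three ring bonds from the ring nitrogen, shows trifluoromethyl in place of hydrogen giving an at least 1.8-fold lower number from compound 3 to compound 4 (0.27 log units; that floor lies within the scatter). From the compounds shown here alone, compound 4 gives this position its first single number, against which other groups can be set, but the step is only a floor, so its true size stays unknown and it may or may not exceed the scatter. Compound 3 remains a limit and not a number: the limit of > 300000 nM in this assay, at which 1 of the 4 values shown sits.

The compounds shown leave open what a hydroxyl group or an amine would give at this same ring carbon in place of trifluoromethyl. Also open, going by these compounds, is whether the change from piperidin-1-yl to 4-(trifluoromethyl)piperidin-1-yl would give a similar step with a longer chain in place of the methyl on the shared core.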